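A Sulfamoyl Chain in Place of Hydroxysulfamoyl

A few compounds are considered here, and "the series" means these few. Any claim that something is new, unique, unknown or untested is made for them only; others in the source may bear on it.

Compound 3 `O=S(=O)(CCNc1nonc1/C(=N/O)Nc1ccc(F)c(Br)c1)NO` carries a 2-(hydroxysulfamoyl)ethyl group on a nitrogen on an aromatic ring of the shared core. In an assay on HeLa cells for inhibition of Indoleamine 2,3-dioxygenase 1 (Homo sapiens), read by spectrophotometry, with a stated time of 24 h (a lower number here means that less compound is needed, a higher number that more compound is needed for the effect), compound 3 gives > 800 nM, which is a limit of the assay rather than a measured number. Compound 1 `CS(=O)(=O)NNc1nonc1/C(=N/O)Nc1ccc(F)c(Br)c1` bears a methanesulfonamido group at that nitrogen, and in this assay compound 1 gives > 800 nM, again only a limit. Compound 2 `NNS(=O)(=O)CCNc1nonc1/C(=N/O)Nc1ccc(F)c(Br)c1` carries a 2-(aminosulfamoyl)ethyl chain there, and in this assay compound 2 gives > 800 nM, also a limit. Because (the limit of > 800 nM in this assay, at which 3 of the 3 values shown sit), the steps among these compounds cannot be read: a step that the two limits leave unreadable from compound 1 to compound 2, a step that the two limits leave unreadable from compound 1 to compound 3 and a step that the two limits leave unreadable from compound 2 to compound 3 remain unreadable in both size and direction.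

Compound 4 `NS(=O)(=O)CCCNc1nonc1/C(=N/O)Nc1ccc(F)c(Br)c1` differs from compound 3 in one place: sulfamoylmethyl in place of hydroxysulfamoyl on a saturated chain carbon, two bonds along the chain from a nitrogen on an aromatic ring. Every measured step is unreadable, so none supplies a usable size for this change. With each measured value resting at the limit, compound 4 is expected to give 2000 nM in this assay, within a range from 600 nM to 8000 nM. The step from compound 3 to compound 4 is estimated as a step that the limit leaves unreadable from compound 3 to compound 4, with no movement beyond the scatter expected.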

Compound 4, half-maximal effective concentration: 15 nM
For compound 4 the middle estimate is 130-fold (2.12 log units) above the measured one; the measured number lies below the stated range.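

In this assay, sulfamoylmethyl in place of hydroxysulfamoyl on a saturated chain carbon, two bonds along the chain from a nitrogen on an aromatic ring, gives an at least 53-fold lower number from compound 3 to compound 4 (1.72 log units; beyond the scatter), and the same group in place of aminosulfamoyl gives an at least 53-fold lower number from compound 2 to compound 4 (1.72 log units; beyond the scatter). Among these compounds, with 3-sulfamoylpropyl in place of methanesulfonamido on a nitrogen on an aromatic ring, the result is an at least 53-fold lower number from compound 1 to compound 4 (1.72 log units; beyond the scatter), which shows for the first time that the group carried at this nitrogen can move the number by a large amount. The steps among compound 1, compound 2 and compound 3 still cannot be read, and the true size of each new step remains unknown beyond its stated minimum, because one end of each rests on a limit: the limit of > 800 nM in this assay, at which 3 of the 4 values shown sit.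

Compound 4 differs from compound 3 both by an extra chain carbon and by the missing hydroxy on the sulfonamide nitrogen, and the compounds shown do not tell which of these carries the step; a 2-sulfamoylethyl or a 3-(hydroxysulfamoyl)propyl group at the same nitrogen would separate the two. From the compounds shown here alone, whether a longer chain such as 4-sulfamoylbutyl, or a carboxylic acid at the chain end, would keep a number this low also stays open.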